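Bromo in Place of Methyl: Expecting Little Change

A few compounds are considered here, and "the series" means these few. Any claim that something is new, unique, unknown or untested is made for them only; others in the source may bear on it.

Compound 1 `COc1cc(C(=O)c2ccccc2)ccc1NC(=O)C(C)(O)C(F)(F)F`: 6100 nM
Compound 2 `Cc1cc(C(=O)c2ccccc2)ccc1NC(=O)C(C)(O)C(F)(F)F`: 5000 nM

Both were tested in a functional assay (Cavia porcellus) with sulfonylurea receptors; K-ATP channels (Homo sapiens) as the target; on this read-out higher numbers stand for weaker inhibition and lower numbers for stronger inhibition. Compound 2 sits at one end of these two numbers and compound 1 at the other, but the step of a 1.2-fold lower number from compound 1 to compound 2 (0.09 log units; within the scatter) lies within the scatter. The unmeasured compound 3 `CC(O)(C(=O)Nc1ccc(C(=O)c2ccccc2)cc1Br)C(F)(F)F` differs from compound 2 by bromo in place of methyl on an aromatic carbon. Among the measured compounds shown here, no measured step exchanges a halogen for a carbon group; the only measured change, a 1.2-fold lower number from compound 1 to compound 2 (0.09 log units; within the scatter), was small, so nothing here points to a shift in this assay beyond the scatter. Compound 3 is therefore expected to give 5000 nM, within 2500 nM to 10000 nM. The expected step is no change at the digits printed from compound 2 to compound 3 (within the scatter).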

Compound 3, half-maximal inhibitory concentration: > 30000 nM
Compound 3: a limit, no number; the forecaster's own chance of this, stated with the estimate: 5%; middle value at least 6.0-fold (0.77 log units) from the limit.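

In this assay compound 3 gives a limit and not a number: the limit of > 30000 nM in this assay, at which 1 of the 3 values shown sits.
Methoxy and methyl at this position gave values within the scatter of each other, so the earlier pair suggested a tolerant position, but the change to bromo shows that the group here can matter. Bromo in place of methyl gives an at least 6.0-fold higher number from compound 2 to compound 3 (0.77 log units; beyond the scatter) and bromo in place of methoxy gives an at least 4.9-fold higher number from compound 1 to compound 3 (0.69 log units; beyond the scatter) on the same read-out.

The compounds shown leave open whether this shift belongs to bromo alone or extends to other groups at this position, such as chloro, fluoro or a nitrile.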